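Diyne alcohols: ketone side chain on two chain ends

The source may hold more compounds than are shown below. What is called first, only, known or untested is meant among the compounds shown, and "the series" means these compounds.

Compound 1 `C=CCCCCCC#CC#CCO` ends its chain in a vinyl group; in a functional assay on HCT-15 cells (Homo sapiens) for cytotoxicity (a lower number here means that less compound is needed, a higher number that more compound is needed for the effect), compound 1 gives 12.9 ug/mL. Compound 2 `C=CCCCCCC#CC#CC(O)CC(C)=O` differs from compound 1 by 2-oxopropyl in place of hydrogen on a saturated chain carbon bound to an oxygen on a saturated carbon and a triple-bonded carbon. In this assay compound 2 gives 3.42 ug/mL; the step of a 3.8-fold lower number from compound 1 to compound 2 (0.58 log units; beyond the scatter). Compound 3 `CCCCCCCC#CC#CCO` has the other core, which differs from that of compound 1 by ethyl in place of vinyl on a saturated chain carbon, five bonds along the chain from a triple-bonded carbon. In this assay compound 3 gives 5.9 ug/mL; the step of a 2.2-fold lower number from compound 1 to compound 3 (0.34 log units; beyond the scatter). The numbers for compound 2 and compound 3 lie within the scatter of each other, so nothing is said about their order.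

Compound 4 `CCCCCCCC#CC#CC(O)CC(C)=O` is not yet measured in this assay. It differs from compound 3 by 2-oxopropyl in place of hydrogen on a saturated chain carbon bound to an oxygen on a saturated carbon and a triple-bonded carbon. This is the same change as from compound 1 to compound 2, at the same place: a saturated chain carbon bound to an oxygen on a saturated carbon and a triple-bonded carbon. The change occurs twice among these four compounds and has been measured once, on the vinyl core only; whether the saturated core carries it equally is not known from these data.

The step from compound 3 to compound 4 is expected to be a 3.3-fold lower number from compound 3 to compound 4 (0.52 log units; beyond the scatter), beside the earlier 3.8-fold lower number from compound 1 to compound 2 (0.58 log units; beyond the scatter), with a little allowance for the change landing on a different core. Among the measured compounds shown here, this expectation rests on the one measured instance of the change applied to the number for compound 3, 5.9 ug/mL. Compound 4 is therefore estimated at 1.8 ug/mL in this assay, with an expected range from 0.9 ug/mL to 3.6 ug/mL.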

Compound 4, concentration for half-maximal effect: 3.73 ug/mL
Compound 4: middle estimate off by 2.1-fold (0.32 log units), on the low side, outside the stated range (above it).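

In this assay, 2-oxopropyl in place of hydrogen on the saturated chain carbon bound to the oxygen gives a 1.6-fold lower number from compound 3 to compound 4 (0.20 log units; within the scatter) on the core of compound 3, and set against the same change on the core of compound 1, the two steps cannot be told apart: the same change on two cores in this assay, a 3.8-fold lower number (0.58 log units; beyond the scatter) from compound 1 to compound 2 and a 1.6-fold lower number (0.20 log units; within the scatter) from compound 3 to compound 4, 2.4-fold (0.38 log units) apart, within the scatter of two such steps. The exchange of vinyl for ethyl, read with 2-oxopropyl present, gives a 1.1-fold higher number from compound 2 to compound 4 (0.04 log units; within the scatter), and this too cannot be told apart from the same exchange read without that group: the same change on two cores in this assay, a 2.2-fold lower number (0.34 log units; beyond the scatter) from compound 1 to compound 3 and a 1.1-fold higher number (0.04 log units; within the scatter) from compound 2 to compound 4, 2.4-fold (0.38 log units) apart, within the scatter of two such steps. The data therefore show no measurable dependence of either change on the core, but they do not show that the changes carry over equally, since each comparison rests on a single pair of steps and the 2-oxopropyl step is beyond the scatter on one core and within it on the other.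

On these data alone, whether the 2-oxopropyl step on the core of compound 3 is real or is lost in the scatter remains open, and repeat values for these compounds would be needed to settle it. Also open, as far as these compounds go, is how a carboxylic acid or an amine would behave in place of 2-oxopropyl, and how a longer chain would behave in place of the ethyl end.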